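The source may report more compounds than this note shows. Statements on the series, on what has been measured and on what is new or still open speak of the compounds shown alone.

Measured so far:
- compound 1 `O=C(CCC(=O)OCCCCCCSc1ccc([N+](=O)[O-])c2nonc12)Nc1ccccc1F`: in an assay on isolated protein for inhibition of glutathione S-transferase P (Homo sapiens), with a stated time of 10 min (on this read-out lower numbers stand for stronger inhibition and higher numbers for weaker inhibition), compound 1 gives 9890 nM
- compound 2 `O=C(CCC(=O)OCCCCCCSc1ccc([N+](=O)[O-])c2nonc12)Nc1ccccc1Cl`: in this assay compound 2 gives 15500 nM

Compound 2 carries the highest of the two numbers, but its distance from compound 1 is small: a 1.6-fold higher number from compound 1 to compound 2 (0.20 log units; within the scatter), which does not separate the two compounds.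

Compound 3 `COc1ccccc1NC(=O)CCC(=O)OCCCCCCSc1ccc([N+](=O)[O-])c2nonc12` differs from compound 2 by methoxy in place of chloro on an aromatic carbon. Among the compounds with values here, the only measured step that bears on this exchange is the one from compound 1 to compound 2, where swapping one small group for another on the same aromatic carbon gave a 1.6-fold higher number from compound 1 to compound 2 (0.20 log units; within the scatter). A second swap at that carbon is therefore expected to leave this assay much where it is, with a 1.3-fold lower number from compound 2 to compound 3 (0.11 log units; within the scatter) as the expected step and no direction favoured beyond the scatter. The estimate for compound 3 in this assay is 12000 nM, with a range from 5000 nM to 30000 nM.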

Compound 3, half-maximal inhibitory concentration: 4050 nM
Compound 3: middle estimate off by 3.0-fold (0.47 log units), on the high side; measured number below the stated range.
By their numbers in this assay, from the lowest: compound 3; then compounds 1 and 2 (each within the scatter of the next).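

At this aromatic carbon, ortho to a large group, the number in this assay does respond to the group placed there: methoxy in place of chloro gives a 3.8-fold lower number from compound 2 to compound 3 (0.58 log units; beyond the scatter) and methoxy in place of fluoro gives a 2.4-fold lower number from compound 1 to compound 3 (0.39 log units; beyond the scatter). Chloro and fluoro could not be separated from each other, whereas both steps to methoxy lie beyond the scatter, though they are modest in size. Compound 3 therefore holds the lowest number of the three, and nothing measured here explains what sets methoxy apart from the other two groups.

From the compounds shown here alone, whether the lower number is particular to methoxy or also appears with ethoxy, a hydroxyl or an amine on the same carbon stays open. Also open, going by these compounds, is whether the step from chloro to methoxy survives a longer chain between the two ends of the molecule.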